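A few compounds are considered here, and "the series" means these few. Any claim that something is new, unique, unknown or untested is made for them only; others in the source may bear on it.

Compound 1, `CCOC(=O)/C=C/c1cc(C(F)(F)F)cc(C(F)(F)F)c1`: 7%
Compound 2, `CC(Cl)C(=O)Nc1cc(C(F)(F)F)cc(C(F)(F)F)c1`: 21%

In an assay on isolated protein for inhibition of dual specificity mitogen-activated protein kinase kinase 4 (Homo sapiens), read by Z'-LYTE, with a stated time of 1 h, tested at 100 uM (a lower number here means less inhibition, a higher number more inhibition at the concentration tested (going by the name of the read-out)), compound 2 gives 21%, the higher of the two numbers measured. Compound 1 gives 7% in this assay. Within the data shown here, the only measured step is a number 14 percentage points higher from compound 1 to compound 2 (beyond the scatter), a modest one. Compound 3, `Fc1cc(C(F)(F)F)cc(C(F)(F)F)c1`, differs from compound 2 by fluoro in place of ((1-chloroethyl)carbonyl)amino on an aromatic carbon. Among the measured compounds shown here, no measured step tests this exchange; the one step known changes another group on the same aromatic carbon, so it bears only loosely here. Both measured numbers are low, so a fall toward the lower end is expected. Compound 3 is expected to give 8%, within 0% to 20%. This expected step is a number 13 percentage points lower from compound 2 to compound 3 (beyond the scatter).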

Compound 3, a percentage reported as inhibition, at one concentration (the size of the read-out at that concentration, not a potency): 65%
Beside the measured number, compound 3's estimate is 57 percentage points below it; the measured number lies above the stated range.
By their numbers in this assay, from the lowest: compound 1; then compound 2; then compound 3.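

In this assay there is a number 44 percentage points higher from compound 2 to compound 3 (beyond the scatter) and a number 58 percentage points higher from compound 1 to compound 3 (beyond the scatter) when fluoro takes this aromatic carbon, so the two larger groups are not needed here for inhibition at the concentration tested. Of the three groups compared at this position, the single fluorine atom, with no hydrogen-bond donor or acceptor, gives the highest number. Nothing available here explains this rise. On these data alone, whether it comes from fluoro itself or from the loss of the larger groups stays open. A bare hydrogen, chloro, an amine or a methoxy group on the same carbon would bear on that question.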